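Swapping a Hydroxybenzyl Ether for a Hydroxycyclohexyl Ether

This account rests on a few compounds, and the source may have more. Where it says the series, first, only, none or still open, it means among the compounds named here.

Compound 3 `O=[N+]([O-])c1ccc(NC(=S)NCCNS(=O)(=O)c2ccc(-c3ccccc3OCc3cccc(O)c3)s2)cc1` and compound 1 `O=[N+]([O-])c1ccc(NC(=S)NCCNS(=O)(=O)c2ccc(-c3ccccc3O[C@H]3CC[C@@H](O)CC3)s2)cc1` share a core and differ only in one place: 4-hydroxycyclohexyl in place of 3-hydroxybenzyl on an oxygen on an aromatic ring. In a functional assay on RS4-11 cells (Homo sapiens) for inhibition, read by CCK-8 assay, with a stated time of 48 h (a lower number here means a stronger inhibitor, a higher number a weaker inhibitor), compound 3 gives 10100 nM, and compound 1 gives 9400 nM; the step of a 1.1-fold lower number from compound 3 to compound 1 (0.03 log units; within the scatter) leaves the two values indistinguishable. Compound 2 `O=C(NCCNS(=O)(=O)c1ccc(-c2ccccc2OCc2cccc(O)c2)s1)Nc1cc(C(F)(F)F)cc(C(F)(F)F)c1` rests on a different core, and the difference between the two cores is not broken down here. In this assay compound 2 gives 3000 nM, the lowest of the three measured values. Compound 4 `O=C(NCCNS(=O)(=O)c1ccc(-c2ccccc2O[C@H]2CC[C@@H](O)CC2)s1)Nc1cc(C(F)(F)F)cc(C(F)(F)F)c1` carries the same change as before: 4-hydroxycyclohexyl in place of 3-hydroxybenzyl on an oxygen on an aromatic ring. Because the earlier step of a 1.1-fold lower number from compound 3 to compound 1 (0.03 log units; within the scatter) stayed within the scatter, the step from compound 2 to compound 4 is expected to be small, about a 1.1-fold lower number from compound 2 to compound 4 (0.03 log units; within the scatter). Compound 4 is therefore estimated at 2800 nM, with a likely range from 1400 nM to 6000 nM.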

Compound 4, half-maximal inhibitory concentration: 9300 nM
Compound 4: middle estimate off by 3.3-fold (0.52 log units), on the low side; measured number outside the range, above it.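

On the core of compound 2, the change from 3-hydroxybenzyl to 4-hydroxycyclohexyl gives a 3.1-fold higher number from compound 2 to compound 4 (0.49 log units; beyond the scatter), so the flat result on the core of compound 3 did not carry over. The two steps differ in this assay: the same change on two cores in this assay, a 1.1-fold lower number (0.03 log units; within the scatter) from compound 3 to compound 1 and a 3.1-fold higher number (0.49 log units; beyond the scatter) from compound 2 to compound 4, 3.3-fold (0.52 log units) apart, beyond the scatter of two such steps. This shows that a change that does little on one core cannot be assumed to do little on another in this series, but two pairs do not show which difference between the cores matters, or why.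

As far as these compounds go, it remains open how the same change would behave on any further core. From the compounds shown here alone, it is also open whether an amine, as in a 4-aminocyclohexyl group on the same oxygen, would respond to the core in the same way.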